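Ortho-halophenyl to dimethylphenyl on the piperazine

A few compounds are considered here, and "the series" means these few. Any claim that something is new, unique, unknown or untested is made for them only; others in the source may bear on it.

Compound 3 `CCCc1nc(-c2ccccc2)c(CNCCCN2CCN(c3ccccc3F)CC2)o1` stands second highest of the three measured compounds in an assay on HEK293 cells for inhibition of Voltage-dependent T-type calcium channel subunit alpha-1G (Homo sapiens), read by fluorescence, tested at 10 uM (on this read-out higher numbers stand for more inhibition at the one concentration tested (going by the name of the read-out) and lower numbers for less inhibition), where compound 3 gives 54.4%. Compound 2 `CCCc1nc(-c2ccccc2)c(CNCCCN2CCN(c3ccccc3Cl)CC2)o1` gives 64.7%, and compound 1 `CCCc1nc(-c2ccccc2)c(CNCCCN2CCN(c3ccc(OC)cc3)CC2)o1` gives 42.1%. The change to compound 4 `CCCc1nc(-c2ccccc2)c(CNCCCN2CCN(c3ccc(C)c(C)c3)CC2)o1` is 3,4-dimethylphenyl in place of 2-fluorophenyl on an amine nitrogen in a ring. Among the measured compounds shown here, the steps that bear on it all concern the aryl group on the same ring nitrogen: a number 12.3 percentage points higher from compound 1 to compound 3 (beyond the scatter), a number 22.6 percentage points higher from compound 1 to compound 2 (beyond the scatter) and a number 10.3 percentage points lower from compound 2 to compound 3 (beyond the scatter). None involves a dimethylphenyl, so the direction is uncertain; only compound 1 shows that a phenyl without a 2-halo substituent can fall lower. Compound 4 is therefore expected to give roughly 48%, between 30% and 66%, an estimated step of a number 6.4 percentage points lower from compound 3 to compound 4 (within the scatter).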

Compound 4, a percentage reported as inhibition, at one concentration (the size of the read-out at that concentration, not a potency): 54.6%
Estimate against measurement, compound 4: 6.6 percentage points below, within the range that was stated.
By their numbers in this assay, from the lowest: compound 1; then compounds 3 and 4 (each within the scatter of the next); then compound 2.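

In this assay the 3,4-dimethylphenyl group, which carries no halogen, cannot be told apart from 2-fluorophenyl on this ring nitrogen, with a number 0.2 percentage points higher from compound 3 to compound 4 (within the scatter) as the step, so among these compounds a 2-halo substituent is not required to reach that level. The same group still gives a number 10.1 percentage points lower from compound 2 to compound 4 (beyond the scatter) against 2-chlorophenyl and a number 12.5 percentage points higher from compound 1 to compound 4 (beyond the scatter) against 4-methoxyphenyl, which leaves 2-chlorophenyl on top of this set. Nothing available explains these differences. From the compounds shown here alone, how a plain phenyl, a pyridyl or a benzyl group on this nitrogen would compare remains open.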